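The source may report more compounds than this note shows. Statements on the series, on what has been measured and on what is new or still open speak of the compounds shown alone.

Measured so far in a functional assay on CHO cells for agonist activity at metabotropic glutamate receptor 2 (Homo sapiens); on this read-out lower numbers stand for smaller maximal responses and higher numbers for larger maximal responses:
- compound 1 `N#Cc1c(-c2ccc3c(ccn3CC3CC3)c2)ccn2c(CC(F)(F)F)cnc12`: 230%
- compound 2 `N#Cc1c(-c2cc(Cl)c3c(ccn3CC3CC3)c2)ccn2c(CC(F)(F)F)cnc12`: 200%
- compound 3 `N#Cc1c(-c2ccc(OC3CCOCC3)c(Cl)c2)ccn2c(CC(F)(F)F)cnc12`: 173%

Compound 1 stands highest of the three numbers in this assay. Its nearest neighbour is compound 2, and the step of a number 30 percentage points lower from compound 1 to compound 2 (beyond the scatter) is beyond the scatter. Compound 3 lies furthest away, its value being well under that of compound 1.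

Compound 4 `N#Cc1c(-c2ccc3c(ccn3C3CCOCC3)c2)ccn2c(CC(F)(F)F)cnc12` differs from compound 1 in one place: oxan-4-yl in place of cyclopropylmethyl on an aromatic nitrogen.

Among the compounds with values here, none of the measured steps touches the group on the aromatic nitrogen. Within the data shown here, the only step available, a number 30 percentage points lower from compound 1 to compound 2 (beyond the scatter), concerns a chloro on an aromatic carbon and therefore says nothing direct about the present change. Among the measured compounds shown here, compound 3 also carries an oxan-4-yl, but its core differs from that of compound 1 in more than one place, so only its bare number is known and no step can be drawn from it. For the measured compounds named here, with no step bearing on the change, the expectation for compound 4 rests on compound 1 alone, and a step within the scatter or a modest fall is expected, a number 20 percentage points lower from compound 1 to compound 4 (beyond the scatter).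

For compound 4 in this assay the estimate is 210%, with a range from 160% to 250%.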

Compound 4, largest response reached (Emax), in percent of the reference or control that the assay uses: 442%
For compound 4 the middle estimate is 232 percentage points below the measured one; measured number outside the range, above it.
By their numbers in this assay, from the lowest: compound 3; then compound 2; then compound 1; then compound 4.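

In this assay, within the data shown here, the group on the aromatic nitrogen proves to be a place where a single change moves the maximal response a long way: oxan-4-yl in place of cyclopropylmethyl gives a number 212 percentage points higher from compound 1 to compound 4 (beyond the scatter) and so runs opposite in direction to the only earlier step, a number 30 percentage points lower from compound 1 to compound 2 (beyond the scatter) on an aromatic carbon. The position therefore accepts oxan-4-yl, with 6 heavy atoms and 1 hydrogen-bond acceptor, in place of cyclopropylmethyl, with 4 heavy atoms and 0 hydrogen-bond acceptors, and the response rises rather than merely holding. No measurement shown here accounts for this rise, and this one pair cannot separate the size of the ring from its oxygen.

From the compounds shown here alone, a cyclohexyl or a piperidin-4-yl on the same aromatic nitrogen would bear on that question, and it remains open how the response would change with either group. Also open, going by these compounds, is whether oxan-4-yl would give a similar rise on the chloro-bearing core of compound 2, since the two changes are seen here only apart.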